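This account rests on a few compounds, and the source may have more. Where it says the series, first, only, none or still open, it means among the compounds named here.

Measured so far in an ADME assay on S9 fraction from liver (Mus musculus) for metabolic stability, read by LC-MS, using NADPH, with a stated time of 60 min, tested at 1 uM; a higher number here means that the compound lasts longer, a lower number that the compound disappears faster:
- compound 1 `Cc1ccccc1N(C)C(=O)c1ccc(-c2ccc(OS(N)(=O)=O)cc2)o1`: 0.417 h
- compound 2 `Cc1ccccc1N(C)C(=O)c1ccc(-c2ccc(OS(N)(=O)=O)c(Cl)c2)o1`: 0.517 h
- compound 3 `Cc1ccccc1N(C)C(=O)c1ccc(-c2ccc(OS(N)(=O)=O)c(F)c2)o1`: 0.102 h

Compound 1 stands level with compound 2, since their two values lie within the scatter of each other, while compound 3 sits clearly lower than both. The next compound to be measured, compound 4 `Cc1ccccc1N(C)C(=O)c1ccc(-c2ccc(OS(N)(=O)=O)cc2Cl)o1`, keeps the core of compound 1 and makes a single change: chloro in place of hydrogen on an aromatic carbon. This is chloro in place of hydrogen on an aromatic carbon, ortho to a large group and meta to a sulfamoyloxy group.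

For the measured compounds named here, two measured steps bear on this change. The closest is the other chloro step, a 1.2-fold higher number from compound 1 to compound 2 (0.09 log units; within the scatter), but compound 2 carries its chloro at a different place on the ring, so it is only a partial guide. The fluoro step, a 4.1-fold lower number from compound 1 to compound 3 (0.61 log units; beyond the scatter), shows that one small substituent on this ring can matter in this assay, and a 5.1-fold lower number from compound 2 to compound 3 (0.70 log units; beyond the scatter) points the same way. Three compounds are too few for a rule.

Going by compound 2 and its step of a 1.2-fold higher number from compound 1 to compound 2 (0.09 log units; within the scatter), no change beyond the scatter is expected, although a drop remains possible. The expected step is a 1.1-fold lower number from compound 1 to compound 4 (0.04 log units; within the scatter). For compound 4 the estimated half-life is 0.38 h, with an expected range from 0.14 h to 0.9 h.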

Compound 4, half-life: 0.333 h
Beside the measured number, compound 4's estimate is 1.1-fold (0.06 log units) above it, and the stated range covers the measured number.
By their numbers in this assay, from the lowest: compound 3; then compounds 4, 1 and 2 (each within the scatter of the next).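

In this assay, chloro in place of hydrogen on the aromatic carbon ortho to a large group and meta to a sulfamoyloxy group gives a 1.3-fold lower number from compound 1 to compound 4 (0.10 log units; within the scatter), so at this position the added chlorine atom produces no change that can be told apart from the ordinary spread of repeated measurements. Together with a 1.2-fold higher number from compound 1 to compound 2 (0.09 log units; within the scatter), this gives two places on the ring where chloro in place of hydrogen leaves the half-life level, while compound 3 goes against any idea that small substituents on this ring are generally without effect, as its fluoro, at the place of the chloro in compound 2, does lower the number beyond the scatter. Nothing measured here explains why either chloro step stays within the scatter or why the fluoro step does not.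

Going by these compounds, whether fluoro at the position used in compound 4 would behave like the fluoro of compound 3 or like the chloro of compound 4 remains open. Also open, on these data alone, is whether a different group at this position, such as methoxy, an amine or a carboxylic acid, would move the half-life beyond the scatter.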